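The source may hold more compounds than are shown below. What is called first, only, known or untested is meant among the compounds shown, and "the series" means these compounds.

Results in an ADME assay on cells (Hepatocyte, Mus musculus) for metabolic stability, with a stated time of 30 min; a higher number here means that more of the compound is left, a lower number that less of the compound is left

Compound 1 `O=C(OC1CCC(CN2CCN(c3cc(=O)c4cc(C(F)(F)F)cc([N+](=O)[O-])c4s3)CC2)CC1)c1ccco1` gives 0.6%
Compound 2 `O=C(OC1CCC(CN2CCN(c3cc(=O)c4cc(C(F)(F)F)cc([N+](=O)[O-])c4s3)CC2)CC1)c1ccc(C(F)(F)F)cc1` gives 28.8%

Of these two, compound 2 stands higher, at 28.8% in this assay as its reading. Compound 3 `O=c1cc(N2CCN(CC3CCC(O)CC3)CC2)sc2c([N+](=O)[O-])cc(C(F)(F)F)cc12` differs from it by one change hydrogen in place of (4-(trifluoromethyl)phenyl)carbonyl on an oxygen on a saturated carbon in which hydrogen replaces (4-(trifluoromethyl)phenyl)carbonyl on an oxygen on a saturated carbon. Among the measured compounds shown here, only one measured step bears on this, a number 28.2 percentage points higher from compound 1 to compound 2 (beyond the scatter), and it exchanged one group on the carbonyl carbon for another. For the measured compounds named here, no measured compound lacks that carbonyl, so the guide is weak. A modest rise is expected, estimated as a number 13.2 percentage points higher from compound 2 to compound 3 (beyond the scatter) with wide uncertainty. For compound 3 the expected value is 42% with an estimated range from 12% to 72% in this reading.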

Compound 3, percent of the compound remaining: 51.2%
Estimate against measurement, compound 3: 9.2 percentage points below; the range from low to high includes it.
By their numbers in this assay, from the lowest: compound 1; then compound 2; then compound 3.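

Earlier, only the group on the carbonyl carbon had changed; here, in this assay, hydrogen replaces the entire (4-(trifluoromethyl)phenyl)carbonyl on the oxygen, giving a number 22.4 percentage points higher from compound 2 to compound 3 (beyond the scatter). Hydrogen in place of (furan-2-yl)carbonyl gives a number 50.6 percentage points higher from compound 1 to compound 3 (beyond the scatter), so compound 3, with hydrogen on this oxygen, stands above both carbonyl-bearing compounds. Nothing measured here explains this rise.

Still open, as far as these compounds go, is how a methyl ether or an amine at this place would compare with compound 3. So is whether an amide, with its carbonyl kept, would behave like compound 1 and compound 2.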